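Fused-ring aryl substituent series: step to fluoro analogue

The source may report more compounds than this note shows. Statements on the series, on what has been measured and on what is new or still open speak of the compounds shown alone.

Measured so far:
- compound 1 `Cc1ccc2c(c1)CCN2S(=O)(=O)c1ccc(-c2cnc(C3CC3)o2)cc1`: 74.7%
- compound 2 `CS(=O)(=O)c1ccc2c(c1)CCN2S(=O)(=O)c1ccc(-c2cnc(C3CC3)o2)cc1`: 6.54%
- compound 3 `N#Cc1ccc2c(c1)CCN2S(=O)(=O)c1ccc(-c2cnc(C3CC3)o2)cc1`: 37.4%

All three share one core and differ only in the substituent on the six-membered aromatic ring of the fused system. In an ADME assay on HEK-293T cells (Homo sapiens) for inhibition, read by MTT assay, tested at 10 uM (a higher number here means more inhibition at the concentration tested (going by the name of the read-out), a lower number less inhibition), compound 3 stands second highest of the three: its nearest neighbour is compound 2, a number 30.9 percentage points higher from compound 2 to compound 3 (beyond the scatter); the furthest is compound 1, a number 37.3 percentage points lower from compound 1 to compound 3 (beyond the scatter).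

Compound 4 `O=S(=O)(c1ccc(-c2cnc(C3CC3)o2)cc1)N1CCc2cc(F)ccc21` has not yet been measured. Its change from compound 3: fluoro in place of cyano on an aromatic carbon.

Going by the values given here, no measured step swaps cyano for fluoro, so the expectation rests on the two steps that leave or reach compound 3. a number 68.2 percentage points lower from compound 1 to compound 2 (beyond the scatter) and a number 37.3 percentage points lower from compound 1 to compound 3 (beyond the scatter) both show that the methyl of compound 1 was the best of the three groups tried, and the step of a number 30.9 percentage points higher from compound 2 to compound 3 (beyond the scatter) shows recovery when the larger methylsulfonyl is replaced. Fluoro, a single heavy atom with no acceptor, is expected to move the number back toward that of compound 1, so a rise a number 20.6 percentage points higher from compound 3 to compound 4 (beyond the scatter) beyond the scatter is expected. Compound 4 is therefore estimated at 58%, within 35% to 80%.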

Compound 4, a percentage reported as inhibition, at one concentration (the size of the read-out at that concentration, not a potency): 25.7%
Compound 4: the middle estimate sits 32.3 percentage points above what was measured, outside the stated range (below it).
By their numbers in this assay, from the lowest: compound 2; then compound 4; then compound 3; then compound 1.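

Fluoro in place of cyano gives a number 11.7 percentage points lower from compound 3 to compound 4 (beyond the scatter) in this assay and so the loss of a heavy atom and the only hydrogen-bond acceptor of the cyano group does not, at this position, bring the number back toward that of the methyl compound. Fluoro still keeps clear of methylsulfonyl, with a number 19.2 percentage points higher from compound 2 to compound 4 (beyond the scatter) as the step, which places it in the lower part of the range and not at its floor. Methyl stands apart from all three other groups, and a number 49 percentage points lower from compound 1 to compound 4 (beyond the scatter) is the step that shows that even a group of one heavy atom does not match it. Nothing available explains this order.

As far as these compounds go, whether the high number of compound 1 belongs to methyl alone stays open. An ethyl, a chloro or a methoxy group on the same aromatic carbon would test how far it extends.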